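The source may report more compounds than this note shows. Statements on the series, on what has been measured and on what is new or still open speak of the compounds shown alone.

Among the measured compounds shown here, the series is followed here in an ADME assay on microsomes from liver (Rattus norvegicus) for metabolic stability (a lower number here means that the compound disappears faster, a higher number that the compound lasts longer), and only two compounds have a reading so far. Compound 1 `CC(C)[C@@H](c1ccc(-c2ccc3cccc(F)c3c2)[nH]c1=O)[C@@H]1OC(=O)NC1=O` gives 1.27 h as an exact half-life. Compound 2 `CCC(CC)C(/C=C1\OC(=O)NC1=O)c1ccc(-c2ccc3cccc(F)c3c2)[nH]c1=O` gives > 3 h, which is a limit of the assay and not a number. Compound 2 therefore has no exact position, only the limit of > 3 h in this assay, at which 1 of the 2 values shown sits, to place it.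

Compound 3 `O=C1NC(=O)/C(=C/C(c2ccccc2)c2ccc(-c3ccc4cccc(F)c4c3)[nH]c2=O)O1` carries phenyl in place of pentan-3-yl on a saturated chain carbon bound to an aromatic carbon and a double-bonded chain carbon. For the measured compounds named here, no measured pair differs in one place only, so this exchange has no direct precedent and the expectation stays loose.

Going by the values given here, the expectation leans on compound 1 at 1.27 h as the only exact reading available. A moderate fall in this assay is expected, estimated as an at least 1.6-fold lower number from compound 2 to compound 3 (0.22 log units; that floor lies within the scatter), although another reading at the limit remains possible. For compound 3 the estimated half-life is 1.8 h, with an expected range from 0.8 h to 3 h.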

Compound 3, half-life: > 3 h
Compound 3 gave a limit, no number; the forecaster's own chance of this, stated with the estimate: 30%; middle value at least 1.6-fold (0.22 log units) from the limit.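

In this assay compound 3 gives > 3 h, which is a limit and not a number, and compound 2 also stands at a limit, so no step between compound 2 and compound 3 can be read: the limit of > 3 h in this assay, at which 2 of the 3 values shown sit.

The compounds shown leave open whether phenyl in place of pentan-3-yl alters the half-life at all.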